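Removing fluorine from a pyrimidine-linked benzothiazole series

The source may report more compounds than this note shows. Statements on the series, on what has been measured and on what is new or still open speak of the compounds shown alone.

Of the compounds shown here, three of a shared core have been tested in a functional assay on MDA-MB-231 cells (Homo sapiens) for antiproliferative activity, read by MTT assay, with a stated time of 48 h; a lower number here means a stronger inhibitor, a higher number a weaker inhibitor. Compound 1 `CS(=O)(=O)c1ccc(Nc2nccc(Nc3nc4ccc(F)cc4s3)n2)cc1` gives 2080 nM. Compound 2 `CS(=O)(=O)c1ccc(Nc2ncc(F)c(Nc3nc4ccc(F)cc4s3)n2)cc1`, which carries an additional fluoro group, gives 8900 nM. Compound 3 `COc1ccc2nc(Nc3nc(Nc4ccc(S(N)(=O)=O)cc4)ncc3F)sc2c1` gives 26600 nM, the highest number of the three; the difference between its core and that of compound 2 is not broken down here.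

Among the measured pairs there is one counted change, (hydrogen in place of fluoro on an aromatic carbon), which gives the step of a 4.3-fold lower number from compound 2 to compound 1 (0.63 log units; beyond the scatter).

Compound 4 `COc1ccc2nc(Nc3ccnc(Nc4ccc(S(N)(=O)=O)cc4)n3)sc2c1` has not yet been measured. It differs from compound 3 by hydrogen in place of fluoro on an aromatic carbon, and the surroundings of the place are the same as in the change from compound 2 to compound 1, so this is the same change. Since compound 1 showed the step of a 4.3-fold lower number from compound 2 to compound 1 (0.63 log units; beyond the scatter), a step of comparable size is expected from compound 3 to compound 4, namely a 4.1-fold lower number from compound 3 to compound 4 (0.61 log units; beyond the scatter). On that basis compound 4 is estimated to give 6500 nM in this assay , with a plausible range from 2500 nM to 16000 nM.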

Compound 4, half-maximal inhibitory concentration: 6240 nM
Compound 4: the middle estimate sits 1.0-fold (0.02 log units) above what was measured, within the range that was stated.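

In this assay, putting hydrogen in place of fluoro on the aromatic carbon of the six-membered aromatic ring with 2 nitrogen gives a 4.3-fold lower number from compound 3 to compound 4 (0.63 log units; beyond the scatter), and the change carries over between the two cores with no difference in size beyond the scatter: the same change on two cores in this assay, a 4.3-fold lower number (0.63 log units; beyond the scatter) from compound 2 to compound 1 and a 4.3-fold lower number (0.63 log units; beyond the scatter) from compound 3 to compound 4, 1.0-fold (0.00 log units) apart, within the scatter of two such steps. Within these two pairs, then, the step can be read across from one core to the other, and the fluoro-bearing compound gives the higher number on both cores. This rests on two pairs in a single cell assay, however, and it shows neither that the step would hold on a third core nor why the number moves at all.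

The compounds shown leave open how a chloro, methyl or nitrile group would compare with hydrogen and fluoro on that same aromatic carbon. They also leave open how the other differences between the two cores each contribute, since no listed pair isolates any of them.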